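Compound 3: the step from a limit

This account rests on a few compounds, and the source may have more. Where it says the series, first, only, none or still open, it means among the compounds named here.

In a functional assay on the whole organism with Rattus norvegicus as the target (a higher number here means that more compound is needed for the effect, a lower number that less compound is needed), compound 1 `CSc1nc(C)nc(SC)c1NC(=O)N(Cc1ccc(Oc2ccc(F)cc2)cc1)C1CCCCCC1` gives 0.45 mg/kg. Compound 2 `CSc1nc(C)cc(Cl)c1NC(=O)N(Cc1ccc(Oc2ccc(F)cc2)cc1)C1CCCCCC1` stands only at a limit of the assay, > 1 mg/kg, and not at a number. Among the measured compounds shown here, the one measured step, an at least 2.2-fold higher number from compound 1 to compound 2 (0.34 log units; beyond the scatter), is beyond the scatter and was made on the same amide-type nitrogen. Compound 3 `Cc1cc(C)c(NC(=O)N(Cc2ccc(Oc3ccc(F)cc3)cc2)C2CCCCCC2)c(C)n1` changes that place again, carrying 2,4,6-trimethylpyridin-3-yl: a group of 9 heavy atoms (8 carbon, 1 nitrogen; one six-membered aromatic ring with 1 hetero atom) in place of a group of 10 heavy atoms (7 carbon, 1 nitrogen, 1 sulfur, 1 chlorine; one six-membered aromatic ring with 1 hetero atom), on an amide-type nitrogen. Its group keeps one six-membered aromatic ring with 1 hetero atom, as in compound 2, whereas compound 1 has 2 hetero atoms there. On that basis, a return to the 0.45 mg/kg of compound 1 is not expected, though the data cannot exclude it. The expected step is a step that the limit leaves unreadable from compound 2 to compound 3, with no change beyond the scatter anticipated in this assay. For compound 3 the estimated value is 1.2 mg/kg, with an expected range of 0.4 mg/kg to 3.5 mg/kg.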

Compound 3, dose for half-maximal effect: 0.77 mg/kg
Estimate against measurement, compound 3: 1.6-fold (0.19 log units) above, within the range that was stated.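

In this assay compound 3 gives a number where compound 2 gave only a limit, so this place on the amide-type nitrogen now has a reading for a group with one ring hetero atom, 2,4,6-trimethylpyridin-3-yl. The comparison with the sulfur-bearing group of compound 1 is a 1.7-fold higher number from compound 1 to compound 3 (0.23 log units; within the scatter), so neither sulfur nor a second ring hetero atom is needed for a value at that level. The other step, an at least 1.2-fold lower number from compound 2 to compound 3 (0.11 log units; that floor lies within the scatter), is only a floor, and compound 2 remains a limit, not a number: the limit of > 1 mg/kg in this assay, at which 1 of the 3 values shown sits.

As far as these compounds go, whether a phenyl ring with three methyl groups and no ring hetero atom, or a pyridine ring bearing an amine, would hold this level stays open. From the compounds shown here alone, every change shown sits at this one place, so the contribution of the shared remainder of the structure also stays open.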